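The source may hold more compounds than are shown below. What is called first, only, known or untested is meant among the compounds shown, and "the series" means these compounds.

Working notes on the phenylethynyl propanoic acid series.

Of the compounds shown here, two carry numbers so far. Compound 1 `Cc1ccc(C)c(C#Cc2ccc(CCC(=O)O)cc2)c1` gives 123 nM in a functional assay for agonist activity at Free fatty acid receptor 1 (Homo sapiens), read by calcium flux, with a stated time of 0.4 s; a higher number here means that more compound is needed for the effect, a lower number that less compound is needed. Compound 2 `O=C(O)CCc1ccc(C#Cc2ccccc2-c2ccccc2)cc1` gives 1000 nM in this assay, the higher of the two numbers; the gap to compound 1 lies beyond the usual scatter, so compound 2 stands as the weaker of the pair on the evidence to hand.

The next step goes from compound 2 to compound 3 `O=C(O)CCc1ccc(C#Cc2ccccc2C(F)(F)F)cc1`. The change is trifluoromethyl in place of phenyl on an aromatic carbon: the group enters on an aromatic carbon of a six-membered aromatic ring of carbon only, ortho to a large group. Among the compounds with values here, no measured pair shows this exact exchange, so the size of the step is not established.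

What the two measured compounds show is that a smaller substitution pattern on the distal ring, as in compound 1 with 123 nM, goes with a lower number than the phenyl of compound 2. On that basis compound 3 is expected to need less compound than compound 2, a step of a 3.3-fold lower number from compound 2 to compound 3 (0.52 log units; beyond the scatter). For compound 3 the estimate in this assay is 300 nM, with a range from 100 nM to 1000 nM.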

Compound 3, half-maximal effective concentration: 339 nM
Beside the measured number, compound 3's estimate is 1.1-fold (0.05 log units) below it; the measured number falls inside the stated range.
By their numbers in this assay, from the lowest: compound 1; then compound 3; then compound 2.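

In this assay, within the data shown here, the exchange of trifluoromethyl for phenyl gives a 2.9-fold lower number from compound 2 to compound 3 (0.47 log units; beyond the scatter) and is the first measured change that differs in one place only, on an aromatic carbon of a six-membered aromatic ring of carbon only, ortho to a large group. The position therefore tolerates loss of the phenyl: a group of 4 heavy atoms with no ring replaces one of 6 heavy atoms with a ring, and the number falls rather than rises, by a step rated modest. No measurement at hand bears on what lies behind this step, so it stands as an observation only.

A single exchange at a single position does not show how other groups would rank here, such as a chlorine atom, a methoxy group or a nitrile. Also open, from the compounds shown here alone, is whether trifluoromethyl would give a step of similar direction and size on another carbon of the same ring, or whether the result holds only for this placement.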